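The source may report more compounds than this note shows. Statements on the series, on what has been measured and on what is new or still open speak of the compounds shown alone.

Measured compounds in a functional assay on cells (Splenocyte, Mus musculus, strain BALB/c) for inhibition, read by scintillation counting and thymidine incorporation, with a stated time of 72 h; on this read-out lower numbers stand for stronger inhibition and higher numbers for weaker inhibition:
Compound 1 `CC(/C=N/Nc1ccc([N+](=O)[O-])cc1)=N\NC(=O)c1ccc(N)cc1` gives > 12000 nM, a limit of the assay.
Compound 2 `CC(/C=N/Nc1ccc([N+](=O)[O-])cc1)=N\NC(=O)c1ccc(O)cc1` gives 1510 nM.
Compound 3 `CC(/C=N/Nc1ccc([N+](=O)[O-])cc1)=N\NC(=O)c1ccc(C(C)(C)C)cc1` gives > 12000 nM, a limit of the assay.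

Compound 3 thus stands at the limit of > 12000 nM in this assay, at which 2 of the 3 values shown sit, and carries no number of its own. Compound 4 `CC(/C=N/Nc1ccc([N+](=O)[O-])cc1)=N\NC(=O)c1ccc(C(F)(F)F)cc1` differs from it by trifluoromethyl in place of tert-butyl on an aromatic carbon. Within the data shown here, two measured steps touch compound 3: a step that the two limits leave unreadable from compound 1 to compound 3, and an at least 7.9-fold higher number from compound 2 to compound 3 (0.90 log units; beyond the scatter). Neither step replaces tert-butyl, so they set no size for the coming change. With compound 3 at the limit, compound 4 is expected to stay near it, the step of a number no higher from compound 3 to compound 4 (the limit leaves the size open) being the expectation. Compound 4 is estimated at 12000 nM, within 3000 nM to 40000 nM.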

Compound 4, half-maximal inhibitory concentration: > 12000 nM
Compound 4 was reported as a limit (the forecaster's own chance of this, stated with the estimate: 60%); the middle value lies on the limit itself.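

In this assay compound 4 gives > 12000 nM, which is a limit of the assay and not a number. Trifluoromethyl thus joins amino and tert-butyl at this position, leaving hydroxy as the only group shown there with a measured number: the limit of > 12000 nM in this assay, at which 3 of the 4 values shown sit.

Among these compounds, the one readable step is an at least 7.9-fold higher number from compound 2 to compound 4 (0.90 log units; beyond the scatter), while the steps to compound 4 from compound 1 and compound 3 cannot be read.

As far as these compounds go, the order among compound 1, compound 3 and compound 4 stays open. So does whether methoxy or a carboxylic acid at this position would give a number, as hydroxy does.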